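A pyridin-3-yl swap on compound 3

A few compounds are considered here, and "the series" means these few. Any claim that something is new, unique, unknown or untested is made for them only; others in the source may bear on it.

Compound 1 `Cc1cccc(-c2cc(-c3ccoc3)cc(-c3ccc(Cl)s3)n2)c1` gives 880 nM
Compound 2 `Clc1ccc(-c2cc(-c3ccoc3)cc(-c3ccccc3Cl)n2)s1` gives 1100 nM
Compound 3 `Clc1cccc(-c2cc(-c3ccoc3)cc(-c3ccc(Cl)s3)n2)c1` gives 950 nM

All three were read in a functional assay on HCT-15 cells (Homo sapiens) for cytotoxicity, read by ELISA, with a stated time of 4 days (on this read-out higher numbers stand for weaker inhibition and lower numbers for stronger inhibition), and compound 3 is not set apart from the other two. Its steps, a 1.1-fold higher number from compound 1 to compound 3 (0.03 log units; within the scatter) and a 1.2-fold lower number from compound 2 to compound 3 (0.06 log units; within the scatter) in turn, both lie within the scatter. Among the compounds with values here, compound 4 `Clc1ccc(-c2cc(-c3ccoc3)cc(-c3cccnc3)n2)s1` has pyridin-3-yl in place of 3-chlorophenyl on an aromatic carbon as its one change. The remaining exchange at this place, a 1.3-fold higher number from compound 1 to compound 2 (0.10 log units; within the scatter) again, also stayed within the scatter. Within the data shown here, no measured step brings in pyridin-3-yl, so the range is kept wide. The estimated step is a 1.3-fold higher number from compound 3 to compound 4 (0.10 log units; within the scatter) and none beyond the scatter is expected. In this assay compound 4 is expected at 1200 nM with an estimated range from 450 nM to 3500 nM as its spread.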

Compound 4, half-maximal inhibitory concentration: 720 nM
Compound 4: middle estimate off by 1.7-fold (0.22 log units), on the high side; low and high end bracket the measured number.
By their numbers in this assay, from the lowest: compounds 4, 1, 3 and 2 (each within the scatter of the next).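

At this place next to the ring nitrogen, pyridin-3-yl is the first group shown that brings a ring nitrogen and a hydrogen-bond acceptor, and in this assay the number stays within the scatter of all three carbon-only aryl compounds (a 1.3-fold lower number from compound 3 to compound 4 (0.12 log units; within the scatter); a 1.5-fold lower number from compound 2 to compound 4 (0.18 log units; within the scatter); a 1.2-fold lower number from compound 1 to compound 4 (0.09 log units; within the scatter)). This position therefore accepts a ring nitrogen without compound 4 being set apart. No measurement here explains this.

On these data alone, whether a carboxylic acid or an aminomethyl group on this ring would move the number beyond the scatter remains open.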